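Chain length at the ester end of the shared core

This account rests on a few compounds, and the source may have more. Where it says the series, first, only, none or still open, it means among the compounds named here.

Compound 1 `CCCCCOC(=O)CCC(=O)N1CCN(CCCOc2cc3c(Nc4ccc(F)c(Cl)c4)ncnc3cc2OC)CC1` gives 81.2% in a functional assay on A549 cells (Homo sapiens) for cytotoxicity, read by MTT assay, with a stated time of 24 h, tested at 20 uM; a higher number here means a weaker effect of the compound at the concentration tested, a lower number a stronger effect. Compound 2 `CCCCCCOC(=O)CCC(=O)N1CCN(CCCOc2cc3c(Nc4ccc(F)c(Cl)c4)ncnc3cc2OC)CC1` gives 85.1% in this assay, and compound 3 `CCCCCCCCCCCCCCCOC(=O)CCC(=O)N1CCN(CCCOc2cc3c(Nc4ccc(F)c(Cl)c4)ncnc3cc2OC)CC1` gives 91.2%. The steps of a number 3.9 percentage points higher from compound 1 to compound 2 (within the scatter) and a number 10 percentage points higher from compound 1 to compound 3 (within the scatter) and a number 6.1 percentage points higher from compound 2 to compound 3 (within the scatter) all fall within the scatter, so the three numbers are not told apart here.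

Compound 4 `CCCCCCCCCCCCCCCCOC(=O)CCC(=O)N1CCN(CCCOc2cc3c(Nc4ccc(F)c(Cl)c4)ncnc3cc2OC)CC1` is not yet measured. Its difference from compound 3 is methyl in place of hydrogen on a saturated chain carbon, ten or more bonds along the chain from an oxygen next to a carbonyl group. The same kind of change, (methyl in place of hydrogen on a saturated chain carbon, five bonds along the chain from an oxygen next to a carbonyl group), made the step of a number 3.9 percentage points higher from compound 1 to compound 2 (within the scatter); only the place along the chain differs, as those two descriptions show. The cores of the two pairs differ by decyl in place of hydrogen on a saturated chain carbon, five bonds along the chain from an oxygen next to a carbonyl group.

For compound 4 the step of a number 1.8 percentage points higher from compound 3 to compound 4 (within the scatter) is expected to stay small, resting on the step of a number 3.9 percentage points higher from compound 1 to compound 2 (within the scatter). Compound 4 is estimated at 93%, between 84% and 101%.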

Compound 4, a percentage reported as activity, at one concentration (the size of the read-out at that concentration, not a potency): 91.7%
Compound 4: middle estimate off by 1.3 percentage points, on the high side, within the range that was stated.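

In this assay the methyl change stays small on both cores, with a number 0.5 percentage points higher from compound 3 to compound 4 (within the scatter): the same change on two cores in this assay, a number 3.9 percentage points higher (within the scatter) from compound 1 to compound 2 and a number 0.5 percentage points higher (within the scatter) from compound 3 to compound 4, 3.4 percentage points apart, within the scatter of two such steps

The decyl change carries over in the same way, with a number 6.6 percentage points higher from compound 2 to compound 4 (within the scatter): the same change on two cores in this assay, a number 10 percentage points higher (within the scatter) from compound 1 to compound 3 and a number 6.6 percentage points higher (within the scatter) from compound 2 to compound 4, 3.4 percentage points apart, within the scatter of two such steps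

Only a number 10.5 percentage points higher from compound 1 to compound 4 (beyond the scatter) lies beyond the scatter, and it is a modest step, so the series shows agreement among small steps on these saturated ester chains, not a sizeable effect that a change carries from one core to another.

The compounds shown leave open whether the same changes hold on a chain end bearing an amine or a carboxylic acid. They also leave open what a branched chain at the ester end would give in this assay.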